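The compounds below may be only part of what the source reports. "The series", "measured", "known", "first", "only" and "open" are said of these compounds alone.

In an ADME assay on BJ cells (Homo sapiens) for cytotoxicity, with a stated time of 72 h (on this read-out lower numbers stand for an effect already at smaller amounts and higher numbers for an effect only at larger amounts of compound), compound 1 (`C=C[C@](C)(CCCC(C)C)CCc1ccc(O)cc1`) gives > 36600 nM, which is a limit of the assay. Compound 2 (`C=C[C@@](C)(/C=C/c1ccc(O)cc1)CCCO`) gives > 36600 nM, also a limit. Going by the values given here, the measured picture so far is the limit of > 36600 nM in this assay, at which 2 of the 2 values shown sit, so the series has no numeric value and no step between measured compounds to draw on.

Compound 3 (`C=C[C@@](C)(/C=C/c1ccc(O)cc1)CC/C=C(\C)C=O`) differs from compound 2 at one chain end: 2-formylprop-1-en-1-yl in place of hydroxymethyl on a saturated chain carbon, three bonds along the chain from two double-bonded chain carbons. In words, this is 2-formylprop-1-en-1-yl in place of hydroxymethyl on a saturated chain carbon, three bonds along the chain from two double-bonded chain carbons.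

A measurable change could only run towards lower numbers, and another reading at the limit remains quite possible. The estimated at least 1.2-fold lower number from compound 2 to compound 3 (0.08 log units; that floor lies within the scatter) is modest and points towards lower numbers. For compound 3 the expected value is 30000 nM, with an estimated range of 9000 nM to 60000 nM.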

Compound 3, half-maximal effective concentration: > 36600 nM
Compound 3 was reported as a limit; the forecaster's own chance of this, stated with the estimate: 55%; middle value at least 1.2-fold (0.08 log units) away from the limit.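

Compound 3 gives > 36600 nM, a limit of the assay. Going by these compounds alone, with compound 2 also at a limit, no step between compound 2 and compound 3 can be read. The compounds shown leave open whether any chain-end change in this series gives a numeric value on this read-out.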